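The source may hold more compounds than are shown below. What is called first, only, known or untested is meant among the compounds shown, and "the series" means these compounds.

Measured compounds and their values:
- compound 1, `O=C(CCSc1nc2cc(Cl)ccc2o1)N1CCC1`: 3.7 mL/min/g
- compound 2, `O=C(CCSc1nc2cc(Cl)ccc2o1)N1CCCCC1`: 10.7 mL/min/g
- compound 3, `O=C(CCSc1nc2cc(Cl)ccc2o1)NC1CCCC1`: 11.3 mL/min/g

All three share one core and differ only in the group on the carbonyl carbon. In an ADME assay on microsomes from liver (Homo sapiens) for metabolic stability, read by LC-MS, using NADPH, with a stated time of 45 min, tested at 0.5 uM (a higher number here means faster removal of the compound, a lower number slower removal), compound 3 gives 11.3 mL/min/g. Among the compounds with values here, this is the top of the three numbers, but its gap to compound 2, a 1.1-fold higher number from compound 2 to compound 3 (0.02 log units; within the scatter), is within the scatter, so the two cannot be told apart; only the step from compound 1, a 3.1-fold higher number from compound 1 to compound 3 (0.48 log units; beyond the scatter), is a real difference.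

Compound 4, `CCN(CC)C(=O)CCSc1nc2cc(Cl)ccc2o1`, carries the change (diethylamino in place of cyclopentylamino on a carbonyl carbon). Within the data shown here, the steps that bear on it are a 2.9-fold higher number from compound 1 to compound 2 (0.46 log units; beyond the scatter) and a 3.1-fold higher number from compound 1 to compound 3 (0.48 log units; beyond the scatter), which show that the two larger groups both sit above azetidin-1-yl, and a 1.1-fold higher number from compound 2 to compound 3 (0.02 log units; within the scatter), which shows that exchanging one of those larger groups for another changes little. Diethylamino is of similar size to these groups, so no step beyond the scatter is expected in this assay, perhaps a slight drop.

Compound 4 is therefore estimated at 9 mL/min/g, with a range from 4 mL/min/g to 20 mL/min/g. The expected step, a 1.3-fold lower number from compound 3 to compound 4 (0.10 log units; within the scatter), lies within the scatter.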

Compound 4, intrinsic clearance in a liver preparation (reported as CLH), per the amount of preparation that the assay uses: 5.9 mL/min/g
Estimate against measurement, compound 4: 1.5-fold (0.18 log units) above; the measured number falls inside the stated range.
By their numbers in this assay, from the lowest: compounds 1, 4, 2 and 3 (each within the scatter of the next, the first and the last beyond it).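

In this assay the open-chain diethylamino group cannot be told apart from any of the three groups that carry a ring: the steps (a 1.9-fold lower number from compound 3 to compound 4 (0.28 log units; within the scatter)), (a 1.8-fold lower number from compound 2 to compound 4 (0.26 log units; within the scatter)) and (a 1.6-fold higher number from compound 1 to compound 4 (0.20 log units; within the scatter)) all lie within the scatter. The earlier compounds shown here suggested two levels, with azetidin-1-yl set apart from the two larger groups, but compound 4 belongs clearly to neither, so that split looks less clean. A ring on the carbonyl carbon is therefore not required for a number in this range, and the absence of the amide hydrogen in compound 4 brings no step beyond the scatter. No evidence is available to explain these numbers.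

Still open, from the compounds shown here alone, is how a group carrying a basic amine or a carboxylic acid would behave on this carbonyl carbon. Also open, going by these compounds, is whether a longer chain, such as dibutylamino, would separate clearly from compound 1.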